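Benzyl for phenyl on the ether oxygen of compound 2

This account rests on a few compounds, and the source may have more. Where it says the series, first, only, none or still open, it means among the compounds named here.

Measured compounds:
compound 1, `NS(=O)(=O)c1ccc(N2N=C(c3ccc(OCc4ccccc4)cc3)CC2c2ccccc2F)cc1`, 90000 nM
compound 2, `NS(=O)(=O)c1ccc(N2N=C(c3ccc(Oc4ccccc4)cc3)CC2c2cccc(Cl)c2)cc1`, 9000 nM
compound 3, `Cc1ccccc1C1CC(c2ccc(Oc3ccccc3)cc2)=NN1c1ccc(S(N)(=O)=O)cc1`, 7000 nM

In an ADME assay on BHK-21 cells (Mesocricetus auratus) for cytotoxicity, read by MTT assay, with a stated time of 72 h (a higher number here means that more compound is tolerated, a lower number that less compound is tolerated), compound 2 stands second highest of the three numbers. Its nearest neighbour is compound 3, reached by a 1.3-fold lower number from compound 2 to compound 3 (0.11 log units; within the scatter), a step that changes 2-methylphenyl in place of 3-chlorophenyl on a saturated ring carbon. Its furthest neighbour is compound 1, whose number is higher than that of compound 2 by a margin well beyond the scatter.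

The step now followed leads to compound 4, `NS(=O)(=O)c1ccc(N2N=C(c3ccc(OCc4ccccc4)cc3)CC2c2cccc(Cl)c2)cc1`, not yet measured in this assay. The change is benzyl in place of phenyl on an oxygen on an aromatic ring. Among the measured compounds shown here, no measured step isolates this exact change: compound 1 carries the benzyloxy group but also a different group on the saturated ring carbon, and the only measured step, from compound 2 to compound 3, concerns that saturated-ring substituent and lies within the scatter. For the measured compounds named here, the values therefore only show that the one benzyloxy compound, compound 1, sits far above both phenoxy compounds.

On this basis compound 4 is expected to tolerate more compound than compound 2, with an estimated step of a 4.4-fold higher number from compound 2 to compound 4 (0.65 log units; beyond the scatter). Compound 4 is estimated at 40000 nM, within a range from 10000 nM to 120000 nM.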

Compound 4, half-maximal cytotoxic concentration: 45000 nM
Compound 4: middle estimate off by 1.1-fold (0.05 log units), on the low side, within the range that was stated.
By their numbers in this assay, from the lowest: compounds 3 and 2 (each within the scatter of the next); then compounds 4 and 1 (each within the scatter of the next).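

In this assay, the change from phenoxy to benzyloxy can now be read on its own, with 3-chlorophenyl held on the saturated ring carbon: the step gives a 5.0-fold higher number from compound 2 to compound 4 (0.70 log units; beyond the scatter) and stands as a real effect of this change in this pair, which compound 1 could not show because it differs from compound 2 in two places. Among the compounds shown here, with benzyloxy held in place, the saturated ring carbon gives a 2.0-fold lower number from compound 1 to compound 4 (0.30 log units; within the scatter) for the exchange of its aryl group, so this pair, like the phenoxy pair with a 1.3-fold lower number from compound 2 to compound 3 (0.11 log units; within the scatter) as its step, shows no separation from that substituent, and in these compounds the ether group is the only change that carries a step beyond the scatter. The data shown offer no measurement that explains the benzyl step.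

Going by these compounds, whether the same step appears with 2-methylphenyl or 2-fluorophenyl on the saturated ring carbon in a matched phenoxy and benzyloxy pair remains open. Also open, on these data alone, is how a longer chain such as 2-phenylethyl on the oxygen, or a pyridyl ring in place of the benzyl phenyl ring, would read in this cell assay.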